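The compounds below may be only part of what the source reports. "The series", "measured", "known", "first", "only" and "open" are said of these compounds alone.

Compound 1 `COC(=O)N[C@H]1Cc2ccc(NC(=O)c3ccccc3-c3ccc(C(F)(F)F)cc3)cc2C1` gives 1.9 nM in an assay for inhibition of apolipoprotein B-100 (Homo sapiens), tested at 100 nM; on this read-out lower numbers stand for stronger inhibition and higher numbers for weaker inhibition. Compound 2 `COC(=O)N[C@H]1Cc2ccc(NC(=O)c3cc(C)ccc3-c3ccc(C(F)(F)F)cc3)cc2C1` differs from compound 1 by methyl in place of hydrogen on an aromatic carbon and in this assay compound 2 gives 2.2 nM, a step of a 1.2-fold higher number from compound 1 to compound 2 (0.06 log units; within the scatter). Compound 3 `COC(=O)NCC1Cc2ccc(NC(=O)c3cccc(C)c3-c3ccc(C(F)(F)F)cc3)cc2C1` carries a different core; the difference between the two cores is not broken down here. In this assay compound 3 gives 4.1 nM. Compound 4 `COC(=O)NCC1Cc2ccc(NC(=O)c3cc(C)cc(C)c3-c3ccc(C(F)(F)F)cc3)cc2C1`, not yet measured, differs from compound 3 by methyl in place of hydrogen on an aromatic carbon. This is the same kind of change as from compound 1 to compound 2, though the place is not identical, since here it is also meta to a methyl group. A step of about a 1.1-fold higher number from compound 3 to compound 4 (0.04 log units; within the scatter) is expected because the earlier change gave a 1.2-fold higher number from compound 1 to compound 2 (0.06 log units; within the scatter). Compound 4 is estimated at 4.5 nM, expected between 2.3 nM and 9 nM.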

Compound 4, half-maximal inhibitory concentration: 2.2 nM
Beside the measured number, compound 4's estimate is 2.0-fold (0.31 log units) above it; measured number outside the range, below it.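

In this assay methyl in place of hydrogen on an aromatic carbon gives a 1.9-fold lower number from compound 3 to compound 4 (0.27 log units; within the scatter) on the core of compound 3. Set beside the earlier step, this step does not differ from it: the same change on two cores in this assay, a 1.2-fold higher number (0.06 log units; within the scatter) from compound 1 to compound 2 and a 1.9-fold lower number (0.27 log units; within the scatter) from compound 3 to compound 4, 2.2-fold (0.33 log units) apart, within the scatter of two such steps. The change thus stays within the scatter on both cores, but two pairs with the methyl in places that are not identical do not establish a general rule for carrying it to other cores.

The compounds shown leave open how an ethyl group, a methoxy group, an amine or a carboxylic acid would behave in place of this methyl. They also leave open whether a nitrile could stand in place of the trifluoromethyl group.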